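Moving Fluorine Around the Ring on a Hydrazide Arm

A few compounds are considered here, and "the series" means these few. Any claim that something is new, unique, unknown or untested is made for them only; others in the source may bear on it.

Four compounds share one core and differ only in two places. Compound 1 `O=C(NNc1ccccc1F)c1ccc(NS(=O)(=O)c2cnc(O)nc2O)cc1` and compound 2 `O=C(NNc1ccc(F)cc1)c1ccc(NS(=O)(=O)c2cnc(O)nc2O)cc1` differ by 4-fluorophenyl in place of 2-fluorophenyl on an amine nitrogen. In a functional assay on A549 cells (Homo sapiens) for antiproliferative activity, read by MTT assay, with a stated time of 24 h (a higher number here means a weaker inhibitor, a lower number a stronger inhibitor), compound 1 gives 11700 nM. Compound 2 reaches only a limit of this assay, > 20000 nM. The step is an at least 1.7-fold higher number from compound 1 to compound 2 (0.23 log units; that floor lies within the scatter), and its floor rests on (the limit of > 20000 nM in this assay, at which 1 of the 3 values shown sits). Compound 3 `O=C(NNc1ccccc1F)c1cccc(NS(=O)(=O)c2cnc(O)nc2O)c1` has a core whose difference from that of compound 1 is not broken down here; in this assay compound 3 gives 11100 nM. Compound 4 `O=C(NNc1ccc(F)cc1)c1cccc(NS(=O)(=O)c2cnc(O)nc2O)c1` arises from compound 3 by the same change, (4-fluorophenyl in place of 2-fluorophenyl on an amine nitrogen), at the same place. For compound 4 the expected step is a 2.0-fold higher number from compound 3 to compound 4 (0.30 log units; within the scatter), of similar size to the earlier one, because that one read an at least 1.7-fold higher number from compound 1 to compound 2 (0.23 log units; that floor lies within the scatter). Compound 4 is expected to give about 22000 nM, between 11000 nM and 45000 nM, and may itself be reported only as a limit.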

Compound 4, half-maximal inhibitory concentration: > 20000 nM
Compound 4: a limit, no number (the forecaster's own chance of this, stated with the estimate: 60%); the middle value is on the limit's open side.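

Compound 4 gives > 20000 nM in this assay, which is a limit of the assay and not a number. On this core, 4-fluorophenyl in place of 2-fluorophenyl gives an at least 1.8-fold higher number from compound 3 to compound 4 (0.25 log units; that floor lies within the scatter), so the change again ends at the limit, but this floor alone does not establish a real loss of activity on either core. Whether the change has the same size on the two cores cannot be told: the same change on two cores in this assay, an at least 1.7-fold higher number (0.23 log units; that floor lies within the scatter) from compound 1 to compound 2 and an at least 1.8-fold higher number (0.25 log units; that floor lies within the scatter) from compound 3 to compound 4; the limit leaves it open whether they differ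

The compounds shown leave open what a plain phenyl, a chlorophenyl or a methoxyphenyl on that amine nitrogen would give in this assay. They also leave open whether any such group would read clearly apart from compound 3 on this core.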